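From Cyclohexyl to Methoxy: Estimating Transporter Binding

The compounds below may be only part of what the source reports. "The series", "measured", "known", "first", "only" and "open" are said of these compounds alone.

Compound 1 `CCCCC1CNCCN1c1ccc2[nH]ncc2c1`: 31.6 nM
Compound 2 `c1cc2[nH]ncc2cc1N1CCNCC1CC1CCCCC1`: 316 nM

Both were tested in an assay on HEK293 cells for displacement of a labelled ligand from sodium-dependent dopamine transporter (Homo sapiens), read by scintillation proximity assay; on this read-out higher numbers stand for weaker inhibition and lower numbers for stronger inhibition. Going by the values given here, compound 2 gives the highest number of the two; its only neighbour is compound 1, and the step of a 10-fold higher number from compound 1 to compound 2 (1.00 log units; beyond the scatter) separates them, a difference beyond the usual scatter. Compound 3 `COCC1CNCCN1c1ccc2[nH]ncc2c1` has not yet been measured. It differs from compound 2 in one place: methoxy in place of cyclohexyl on a saturated chain carbon bound to a saturated ring carbon. Among the compounds with values here, only one measured step bears on this change, namely a 10-fold higher number from compound 1 to compound 2 (1.00 log units; beyond the scatter), where the cyclohexyl on that chain carbon went with a clearly higher number than propyl did. Removing the cyclohexyl again for methoxy is therefore expected to move the number back down, though the earlier step involved a different entering group, so the size is uncertain. Compound 3 is therefore estimated at 60 nM, with a range from 15 nM to 250 nM. The step this estimate implies is a 5.3-fold lower number from compound 2 to compound 3 (0.72 log units; beyond the scatter).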

Compound 3, inhibition constant: 501 nM
The estimate for compound 3 lay 8.4-fold (0.92 log units) below the measured number, and the stated range ends below it.
By their numbers in this assay, from the lowest: compound 1; then compounds 2 and 3 (each within the scatter of the next).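

Swapping cyclohexyl for methoxy on this saturated chain carbon makes no readable difference in this assay: a 1.6-fold higher number from compound 2 to compound 3 (0.20 log units; within the scatter), even though the two groups share little, one being a ring of six carbons and the other two heavy atoms including an oxygen. The other comparison, a 16-fold higher number from compound 1 to compound 3 (1.20 log units; beyond the scatter), shows that compound 1 with its propyl is the strongest of the three, so both replacements of propyl go with clearly weaker inhibition, whether the entering group is large or small. Nothing available explains why these two different groups give numbers within the scatter of each other.

On these data alone, whether propyl is a special case or one of several good groups here stays open. A longer chain or an amine at this place could help to settle that.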